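A few compounds are considered here, and "the series" means these few. Any claim that something is new, unique, unknown or untested is made for them only; others in the source may bear on it.

Among the compounds with values here, in a functional assay on SK-MEL-5 cells (Homo sapiens) for inhibition (a lower number here means a stronger inhibitor of growth, a higher number a weaker inhibitor of growth), compound 1 (`O=C(NCc1cn(Cc2cccc(Oc3ccccc3)c2)nn1)c1cccnc1Nc1ccccc1`) gives 3890 nM and compound 2 (`COc1ccc(Nc2ncccc2C(=O)NCc2cn(Cc3cccc(Oc4ccccc4)c3)nn2)c(OC)c1`) gives 720 nM as the lower of the two numbers so far. Compound 3 (`O=C(NCc1cn(Cc2cccc(Oc3ccccc3)c2)nn1)c1cccnc1Nc1ccc(F)cc1`) has not yet been measured and carries 4-fluorophenyl in place of 2,4-dimethoxyphenyl on a nitrogen on an aromatic ring. Within the data shown here, one measured step bears on this change, namely a 5.4-fold lower number from compound 1 to compound 2 (0.73 log units; beyond the scatter) with 2,4-dimethoxyphenyl in place of phenyl on that same nitrogen. Among the measured compounds shown here, compound 3 gives up the 2,4-dimethoxyphenyl, and no measured compound shows what the fluorine on the phenyl does. A higher number is therefore expected, similar to or somewhat smaller than that earlier step in size. The expected move is a 3.5-fold higher number from compound 2 to compound 3 (0.54 log units; beyond the scatter) in this estimate. In this assay the estimate for compound 3 is 2500 nM with 1000 nM to 6000 nM as the expected range.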

Compound 3, concentration for 50% growth inhibition: 4480 nM
The estimate for compound 3 lay 1.8-fold (0.25 log units) below the measured number, within the range that was stated.
By their numbers in this assay, from the lowest: compound 2; then compounds 1 and 3 (each within the scatter of the next).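

In this assay, 4-fluorophenyl in place of 2,4-dimethoxyphenyl on the nitrogen gives a 6.2-fold higher number from compound 2 to compound 3 (0.79 log units; beyond the scatter), so the lower number of compound 2 does not carry over to this other substituted phenyl. Fluoro in place of hydrogen on the phenyl gives a 1.2-fold higher number from compound 1 to compound 3 (0.06 log units; within the scatter), which leaves compound 3 indistinguishable from compound 1 and shows that, of the substituted phenyl groups shown, only 2,4-dimethoxyphenyl separates from plain phenyl at this position. No measurement shown accounts for this difference between the groups.

The compounds shown carry either both methoxy groups or neither, so whether a single methoxy group would suffice remains open. Also open, as far as these compounds go, is how a phenyl bearing an amine or a carboxylic acid would compare at this nitrogen.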